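The source may hold more compounds than are shown below. What is called first, only, known or untested is meant among the compounds shown, and "the series" means these compounds.

Measured compounds in a functional assay on the whole organism with Rattus norvegicus as the target, with a stated time of 5 days; a higher number here means that more compound is needed for the effect, a lower number that less compound is needed:

- compound 1 `Cc1cccc(Cl)c1NC(=O)/N=C1\CCCN1C`: in this assay compound 1 gives > 25 mg/kg, which is a limit of the assay and not a number.
- compound 2 `Cc1cccc(NC(=O)/N=C2\CCCN2C)c1`: in this assay compound 2 gives 25 mg/kg.
- compound 3 `CN1CCC/C1=N\C(=O)Nc1cccc(Cl)c1`: in this assay compound 3 gives 15 mg/kg.

Compound 2 and compound 3 differ in one place, (chloro in place of methyl on an aromatic carbon). The measured step is a 1.7-fold lower number from compound 2 to compound 3 (0.22 log units; within the scatter), so the two values are within the scatter of each other and no order between them is claimed.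

Compound 4 `CN1CCC/C1=N\C(=O)Nc1c(Cl)cccc1Cl` has not yet been measured in this assay. It is related to compound 1 by the same kind of change, (chloro in place of methyl on an aromatic carbon). The surroundings are not the same: from compound 2 to compound 3 the place is meta to a large group, whereas from compound 1 to compound 4 the place is ortho to a large group and meta to a chloro group. It is therefore the same kind of change, not the same change. The difference between the core of compound 1 and the core of compound 2 is not broken down here.

For compound 1 only a limit is known, (the limit of > 25 mg/kg in this assay, at which 1 of the 3 values shown sits).

The step from compound 1 to compound 4 is expected to be about a step that the limit leaves unreadable from compound 1 to compound 4, resting on the measured step of a 1.7-fold lower number from compound 2 to compound 3 (0.22 log units; within the scatter), which lies within the scatter. Compound 4 is accordingly estimated at 30 mg/kg in this assay. The range for compound 4 is estimated from 15 mg/kg to 60 mg/kg. Because compound 1 stands at the limit (the limit of > 25 mg/kg in this assay, at which 1 of the 3 values shown sits), a limit rather than a number is considered a likely outcome for compound 4 as well.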

Compound 4, minimum effective dose: > 25 mg/kg
Compound 4 ended at the assay's limit; the forecaster's own chance of this, stated with the estimate: 55%; the middle value does not contradict the limit.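

In this assay, compound 1 and compound 4 both end at a limit and not at a number, so no new step can be read between them: the limit of > 25 mg/kg in this assay, at which 2 of the 4 values shown sit.

The compounds shown leave open whether chloro in place of methyl, ortho to a large group and meta to a chloro group, changes the minimum effective dose at all in this pair.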